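Replacing 4-chlorophenyl on the carbonyl carbon

This account rests on a few compounds, and the source may have more. Where it says the series, first, only, none or still open, it means among the compounds named here.

Among the measured compounds shown here, in a functional assay on ID8 cells (Mus musculus) for antiproliferative activity (on this read-out lower numbers stand for stronger inhibition and higher numbers for weaker inhibition), compound 1 `O=C(Nc1ccc(O)c2c(=O)cc(-c3ccccc3Cl)oc12)c1ccc(Cl)cc1` gives 5500 nM, the lowest of the three numbers measured so far, and its gaps to the other two lie beyond the scatter. Compound 2 `CC(C)C[C@@H](NC(=O)OC(C)(C)C)C(=O)Nc1ccc(O)c2c(=O)cc(-c3ccccc3Cl)oc12` gives 17000 nM, and compound 3 `CSCC[C@@H](NC(=O)OC(C)(C)C)C(=O)Nc1ccc(O)c2c(=O)cc(-c3ccccc3Cl)oc12` gives 13000 nM.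

Compound 4 `C[C@H](NC(=O)OC(C)(C)C)C(=O)Nc1ccc(O)c2c(=O)cc(-c3ccccc3Cl)oc12`, not yet measured, differs from compound 1 in one place: 1-((tert-butoxycarbonyl)amino)ethyl in place of 4-chlorophenyl on a carbonyl carbon. In words, 1-((tert-butoxycarbonyl)amino)ethyl stands in place of 4-chlorophenyl on a carbonyl carbon.

Compound 2 and compound 3 also carry a tert-butoxycarbonyl amino chain on that carbonyl carbon. For the measured compounds named here, the one measured step bearing on this chain, a 1.3-fold lower number from compound 2 to compound 3 (0.12 log units; within the scatter), shows no distinguishable difference between those two chains. Compound 4 is therefore expected to fall with that pair rather than with compound 1 in this assay. The expected step is a 2.7-fold higher number from compound 1 to compound 4 (0.44 log units; beyond the scatter), towards weaker inhibition and beyond the scatter. For compound 4 the estimated value is 15000 nM, with an expected range of 7000 nM to 30000 nM.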

Compound 4, half-maximal inhibitory concentration: 9800 nM
Compound 4: the middle estimate sits 1.5-fold (0.18 log units) above what was measured; the range from low to high includes it.
By their numbers in this assay, from the lowest: compounds 1, 4, 3 and 2 (each within the scatter of the next, the first and the last beyond it).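

In this assay, 1-((tert-butoxycarbonyl)amino)ethyl, which has no ring, stands on the carbonyl carbon in place of 4-chlorophenyl with a 1.8-fold higher number from compound 1 to compound 4 (0.25 log units; within the scatter) and no distinguishable difference, so an aromatic ring at this position is not required to stay within the scatter of compound 1. The earlier values left compound 2 and compound 3 beyond the scatter of compound 1, so a tert-butoxycarbonyl amino chain at this position does not by itself set a compound apart from compound 1. Nothing available explains this result.

The compounds shown leave open how a free primary amine on the same chain carbon, without the tert-butoxycarbonyl group, would read in this assay. Also open, going by these compounds, is whether a carboxylic acid or an unsubstituted phenyl on this carbonyl carbon would stay within the scatter of compound 1.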